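From nitro to amino: compound 2 to compound 3

A few compounds are considered here, and "the series" means these few. Any claim that something is new, unique, unknown or untested is made for them only; others in the source may bear on it.

Compound 1 `O=[N+]([O-])c1c(CS(=O)(=O)c2ccccc2)nc2c(C#Cc3cccnc3)cc(Cl)cn12` and compound 2 `O=[N+]([O-])c1c(CS(=O)(=O)c2ccccc2)nc2c(C#CCCO)cc(Cl)cn12` share a core and were tested in an ADME assay on HepG2 cells (Homo sapiens) for cytotoxicity, read by MTT assay, with a stated time of 72 h; on this read-out lower numbers stand for higher toxicity in this test and higher numbers for lower toxicity in this test. Compound 1 gives > 3900 nM, which is a limit of the assay. Compound 2 gives > 125000 nM, also only a limit. Compound 3 `Nc1c(CS(=O)(=O)c2ccccc2)nc2c(C#CCCO)cc(Cl)cn12` differs from compound 2 at one place, with amino in place of nitro on an aromatic carbon. For the measured compounds named here, the only measured step, a step that the two limits leave unreadable from compound 1 to compound 2, concerns a different group and has no readable size, so it offers no measure for this change. In this assay, the expected move is small and its direction is uncertain, with an at least 1.2-fold lower number from compound 2 to compound 3 (0.09 log units; that floor lies within the scatter) as the estimated step. Compound 3 is estimated at 100000 nM, within an expected range of 30000 nM to 300000 nM.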

Compound 3, half-maximal cytotoxic concentration: > 62500 nM
Compound 3: no number, only a limit; the forecaster's own chance of this, stated with the estimate: 60%; the middle value lies beyond the limit too.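

In this assay compound 3 gives > 62500 nM as a limit. For the compounds shown here, compound 2 gives > 125000 nM as a limit too, so no step between compound 2 and compound 3 can be read. The compounds shown leave open the size and direction of any change with amino in place of nitro on an aromatic carbon.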